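Adding a bromo to compound 3

The compounds below may be only part of what the source reports. "The series", "measured", "known", "first", "only" and "open" are said of these compounds alone.

Measured in a functional assay on K562 cells (Homo sapiens) for cytotoxicity, read by trypan blue exclusion, with a stated time of 96 h; a higher number here means a weaker inhibitor, a lower number a stronger inhibitor:
- compound 1 `COc1cc(OC)c(/C=C/S(=O)(=O)Nc2ccc(OC)c(N)c2)c(OC)c1`: 3 nM
- compound 2 `COC(=O)C(Nc1cc(NS(=O)(=O)/C=C/c2c(OC)cc(OC)cc2OC)ccc1OC)c1ccc(Br)cc1`: 1000 nM
- compound 3 `COc1cc(OC)c(/C=C/S(=O)(=O)Nc2ccc(OC)c(NC(C(=O)O)c3ccccc3)c2)c(OC)c1`: 300 nM

Of these three numbers, compound 3 has the second highest, so it lies between the others. Compound 4 `COc1cc(OC)c(/C=C/S(=O)(=O)Nc2ccc(OC)c(NC(C(=O)O)c3ccc(Br)cc3)c2)c(OC)c1` differs from it by bromo in place of hydrogen on an aromatic carbon, para to a large group: bromo in place of hydrogen on an aromatic carbon.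

Within the data shown here, no measured step isolates this change. The closest is a 3.3-fold lower number from compound 2 to compound 3 (0.52 log units; beyond the scatter), but that step also exchanges methoxycarbonyl for carboxy, so it mixes two changes. The large steps, a 330-fold higher number from compound 1 to compound 2 (2.52 log units; beyond the scatter) and a 100-fold higher number from compound 1 to compound 3 (2.00 log units; beyond the scatter), put a whole group on the nitrogen and say little about a single bromo. Compound 2, which carries the bromo, has the weaker 1000 nM, which hints only faintly at a higher number.

The expected result in this assay is a 1.3-fold higher number from compound 3 to compound 4 (0.12 log units; within the scatter), a small rise that need not exceed the scatter.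

For compound 4 the estimate is 400 nM, with an expected range of 130 nM to 1200 nM.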

Compound 4, half-maximal inhibitory concentration: 75 nM
Compound 4: middle estimate off by 5.3-fold (0.73 log units), on the high side, and the stated range ends above it.
By their numbers in this assay, from the lowest: compound 1; then compound 4; then compound 3; then compound 2.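

Among these compounds, on the phenyl ring of the carboxy(phenyl)methyl group, para to a large group, a single bromo is the only difference, and in this assay it gives a 4.0-fold lower number from compound 3 to compound 4 (0.60 log units; beyond the scatter), so this one atom has a measurable effect that no earlier pair could isolate. With the bromo present on both sides, the swap of methoxycarbonyl for carboxy can also be read alone, and it gives a 13-fold lower number from compound 2 to compound 4 (1.12 log units; beyond the scatter), a large step in the same direction as the bromo step. Even so, placing the whole (4-bromophenyl)(carboxy)methyl group on the nitrogen still leaves a 25-fold higher number from compound 1 to compound 4 (1.40 log units; beyond the scatter), so the free amine keeps the lowest number of the four.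

As far as these compounds go, it remains open whether a chloro, a methyl or a methoxy at this position would lower the number as the bromo does. The data offer no measurement that explains why the bromo lowers the number here.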